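Diethylamino in Place of Dimethylamino, Tried on a Second Core

A few compounds are considered here, and "the series" means these few. Any claim that something is new, unique, unknown or untested is made for them only; others in the source may bear on it.

Compound 1 `CN(C)C/C=C/C(=O)Nc1cc2c(N3CCc4ccccc43)ncnc2cc1O[C@@H]1CCOC1` and compound 2 `CCN(CC)C/C=C/C(=O)Nc1cc2c(N3CCc4ccccc43)ncnc2cc1O[C@@H]1CCOC1` share one core and differ in a single place. In a functional assay on A549 cells (Homo sapiens) for antiproliferative activity, read by MTT assay, with a stated time of 72 h (on this read-out lower numbers stand for stronger inhibition and higher numbers for weaker inhibition), compound 1 gives 1090 nM, while compound 2 gives 5220 nM. The change that separates them, (diethylamino in place of dimethylamino on a saturated chain carbon bound to a double-bonded chain carbon), made a 4.8-fold higher number from compound 1 to compound 2 (0.68 log units; beyond the scatter). Compound 3 `COc1cc2ncnc(N3CCCc4ccccc43)c2cc1NC(=O)/C=C/CN(C)C` rests on another core, and the difference between the two cores is not broken down here. In this assay compound 3 gives 1650 nM, which lies within the usual scatter of compound 1 and beyond it from compound 2. Going by the values given here, compound 4 `CCN(CC)C/C=C/C(=O)Nc1cc2c(N3CCCc4ccccc43)ncnc2cc1OC` carries the same change as the one from compound 1 to compound 2, now on the core of compound 3: diethylamino in place of dimethylamino on a saturated chain carbon bound to a double-bonded chain carbon. The expectation rests on one earlier step only, because that change gave a 4.8-fold higher number from compound 1 to compound 2 (0.68 log units; beyond the scatter). A step of similar direction and size is therefore expected, so that in this assay compound 4 is estimated at 6500 nM, with a range from 2500 nM to 16000 nM. This estimate means an expected step of a 3.9-fold higher number from compound 3 to compound 4 (0.60 log units; beyond the scatter).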

Compound 4, half-maximal inhibitory concentration: 6410 nM
Compound 4: middle estimate off by 1.0-fold (0.01 log units), on the high side, and the stated range covers the measured number.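

In this assay, diethylamino in place of dimethylamino on the core of compound 3 gave a 3.9-fold higher number from compound 3 to compound 4 (0.59 log units; beyond the scatter), the same direction as on the core of compound 1. Set side by side, the two steps do not differ in size beyond what repeated measurements would allow: the same change on two cores in this assay, a 4.8-fold higher number (0.68 log units; beyond the scatter) from compound 1 to compound 2 and a 3.9-fold higher number (0.59 log units; beyond the scatter) from compound 3 to compound 4, 1.2-fold (0.09 log units) apart, within the scatter of two such steps This shows that, for these two cores and in this one assay, the change carried over from one core to the other with its direction and its size intact, but it rests on two matched pairs only, so it does not show that the same would hold on any further core or in any other assay, and it gives no reason for the higher numbers.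

The compounds shown leave open how dipropylamino, or a ring amine such as piperidine or morpholine, would read at the same place on either core. They also leave open whether the higher number seen with diethylamino would appear on cells other than these.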